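The source may hold more compounds than are shown below. What is called first, only, known or untested is meant among the compounds shown, and "the series" means these compounds.

For the measured compounds named here, in a functional assay on the whole organism with Mus musculus as the target (a higher number here means that more compound is needed for the effect, a lower number that less compound is needed), compound 1 `C[C@@H](NCc1ccc(OCc2ccccc2Cl)cc1)C(N)=O` gives 17.4 mg/kg and so holds the lower of the two numbers known so far. Compound 2 `CNC(=O)[C@@H](CO)NCc1ccc(OCc2ccccc2C(F)(F)F)cc1` gives 85.6 mg/kg as the higher number, and that gap lies beyond the usual scatter. These two compounds differ in more than one place, and their gap cannot be pinned on any single group. Compound 3 `C[C@@H](NCc1ccc(OCc2ccoc2)cc1)C(N)=O` keeps the core of compound 1 but carries furan-3-yl in place of 2-chlorophenyl on a saturated chain carbon bound to an oxygen on an aromatic ring while the rest stays the same. Going by the values given here, no measured pair shows this swap, which leaves the expectation as a judgement: a moderate rise in the number, meaning more compound is needed. The expected size of that change is a 1.7-fold higher number from compound 1 to compound 3 (0.24 log units; within the scatter) on this estimate. For compound 3 the estimated dose is 30 mg/kg with an expected range from 12 mg/kg to 75 mg/kg as its upper end.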

Compound 3, dose for half-maximal effect: 152 mg/kg
The estimate for compound 3 lay 5.1-fold (0.70 log units) below the measured number, and the stated range ends below it.
By their numbers in this assay, from the lowest: compound 1; then compounds 2 and 3 (each within the scatter of the next).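

In this assay, replacing 2-chlorophenyl with furan-3-yl on a saturated chain carbon bound to an oxygen on an aromatic ring gives an 8.7-fold higher number from compound 1 to compound 3 (0.94 log units; beyond the scatter), with the rest of the molecule unchanged. For the compounds shown here, this is the first comparison here that isolates one place, and it shows that much more compound is needed with furan-3-yl at this position. The swap changes several things at once, including the ring size, the chlorine and the ring oxygen, and nothing available explains which of them matters.

Going by these compounds, it remains open whether the rise follows from losing the chlorine or from changing the ring, which a plain phenyl group would help to separate. A thiophene ring or a pyridine ring at the same place would show whether other heteroaromatic rings behave like furan-3-yl.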